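The source may report more compounds than this note shows. Statements on the series, on what has been measured and on what is new or still open speak of the compounds shown alone.

Measured compounds:
compound 1, `COc1cccc(-n2cc(CO/N=C3\CC[C@]4(C)[C@@H](CC/C=C(\C)CC/C=C(\C)CCC=C(C)C)[C@](C)(O)CC[C@H]4C3(C)C)nn2)c1`, 51300 nM;
compound 2, `CC(C)=CCC/C(C)=C/CC/C(C)=C/CC[C@@H]1[C@@]2(C)CC/C(=N\OCc3cn(-c4ccc(F)cc4)nn3)C(C)(C)[C@@H]2CC[C@@]1(C)O`, 63100 nM;
compound 3, `COc1cccc(-n2cc(COc3ccc(/C=C4\C[C@]5(C)[C@@H](CC/C=C(\C)CC/C=C(\C)CCC=C(C)C)[C@](C)(O)CC[C@H]5C(C)(C)C4=O)cc3)nn2)c1`, 50100 nM.

All three were tested in a functional assay on HepG2 cells (Homo sapiens) for cytotoxicity, read by MTT assay, with a stated time of 48 h; a higher number here means a weaker inhibitor, a lower number a stronger inhibitor. Compound 1 and compound 2 share one core and differ in a single place: 4-fluorophenyl in place of 3-methoxyphenyl on an aromatic nitrogen. The step this change made, a 1.2-fold higher number from compound 1 to compound 2 (0.09 log units; within the scatter), is small and lies within the usual scatter of repeated measurements, so the two compounds cannot be told apart on this read-out. Compound 3 carries a different core; how the core of compound 1 and the core of compound 3 differ is not broken down here. In this assay compound 3 gives 50100 nM, and its gaps to compound 1 and to compound 2 are both within the scatter, so no ordering among the three can be claimed.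

Compound 4, `CC(C)=CCC/C(C)=C/CC/C(C)=C/CC[C@@H]1[C@@]2(C)C/C(=C\c3ccc(OCc4cn(-c5ccc(F)cc5)nn4)cc3)C(=O)C(C)(C)[C@@H]2CC[C@@]1(C)O`, has not yet been measured. It is related to compound 3 by the same change that relates compound 1 to compound 2: 4-fluorophenyl in place of 3-methoxyphenyl on an aromatic nitrogen. The surroundings of the exchanged group are described in the same words in both pairs, so this is the same change applied to a second core.

Because the earlier step of a 1.2-fold higher number from compound 1 to compound 2 (0.09 log units; within the scatter) was within the scatter, the expected step from compound 3 to compound 4 in this assay, a 1.2-fold higher number from compound 3 to compound 4 (0.06 log units; within the scatter), is also small. Compound 4 is therefore estimated at 58000 nM in this assay, with a likely range from 30000 nM to 115000 nM.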

Compound 4, half-maximal inhibitory concentration: 35900 nM
Compound 4: the middle estimate sits 1.6-fold (0.21 log units) above what was measured; measured number inside the range.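

In this assay, putting 4-fluorophenyl in place of 3-methoxyphenyl on the aromatic nitrogen gives a 1.4-fold lower number from compound 3 to compound 4 (0.14 log units; within the scatter), so on this second core the two compounds again cannot be told apart on this read-out. Set beside the earlier step, the exchange looks the same on both cores as far as this read-out can tell: the same change on two cores in this assay, a 1.2-fold higher number (0.09 log units; within the scatter) from compound 1 to compound 2 and a 1.4-fold lower number (0.14 log units; within the scatter) from compound 3 to compound 4, 1.7-fold (0.23 log units) apart, within the scatter of two such steps. Among the compounds shown here, this shows only that the exchange produced no readable difference on either core; the two steps point in different directions, but both are small enough for that to carry no meaning, and with no step of real size on either core, the pairs cannot show that a real effect would carry from one core to the other.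

The compounds shown leave open whether another group on that aromatic nitrogen, such as a phenyl ring bearing an amine or a carboxylic acid, or a simple alkyl chain in place of the ring, would shift the number beyond the scatter on either core. They also leave open whether a shorter chain in place of the long chain that all four compounds carry would change the picture, and whether any such step would then be the same size on both cores.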